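The compounds below may be only part of what the source reports. "The series", "measured", "known", "first", "only" and "open" are said of these compounds alone.

Compound 1 `COc1ccc(-c2cnc(NC(=O)c3cccnc3)n2C)cc1`: in a toxicity assay on THP-1 cells (Homo sapiens) for inhibition (on this read-out higher numbers stand for lower toxicity in this test and lower numbers for higher toxicity in this test), compound 1 gives only a limit, > 100000 nM.
Compound 2 `COc1ccc(-c2cnc(NC(=O)CCc3ccccc3)n2C)cc1`: compound 2 likewise gives only a limit, > 100000 nM.
Compound 3 `COc1ccc(-c2cnc(NC(C)=O)n2C)cc1`: compound 3 also gives only a limit, > 100000 nM.

Compound 3 therefore stands at the limit with no number of its own, and the same holds for every measured value: the limit of > 100000 nM in this assay, at which 3 of the 3 values shown sit. Compound 4 `COc1ccc(C(=O)Nc2ncc(-c3ccc(OC)cc3)n2C)cc1` differs from compound 3 by 4-methoxyphenyl in place of methyl on a carbonyl carbon. The measured steps all alter the same carbonyl carbon: a step that the two limits leave unreadable from compound 1 to compound 2, a step that the two limits leave unreadable from compound 1 to compound 3 and a step that the two limits leave unreadable from compound 2 to compound 3. None of them can be read, so no size or direction for the step to compound 4 follows from them. For compound 4 the estimate is 100000 nM, in the range 30000 nM to 300000 nM. The step this estimate means, a number no higher from compound 3 to compound 4 (the limit leaves the size open), is expected to be small, with another limit the most likely outcome.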

Compound 4, half-maximal cytotoxic concentration: > 100000 nM
Compound 4 ended at the assay's limit; the forecaster's own chance of this, stated with the estimate: 80%; the middle value lies on the limit itself.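

No step from compound 1, compound 2 or compound 3 to compound 4 can be read, since each value is only a limit: the limit of > 100000 nM in this assay, at which 4 of the 4 values shown sit.

The compounds shown leave open what actual value any of them has in this assay, and whether changing the group on the carbonyl carbon alters it.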